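The compounds below may be only part of what the source reports. "The series", "measured", "known", "first", "only" and "open" are said of these compounds alone.

Working notes on the series. Within the data shown here, compound 1 `C=CC[C@@]12C[C@@H](C(=O)OC)N3[C@@H]1N(C(=N)C31CCCCC1)c1ccccc12` is the one member with a numerical result so far: in a functional assay on MDA-MB-231 cells (Homo sapiens) for cytotoxicity, read by sulforhodamine B assay, with a stated time of 48 h (a lower number here means a stronger inhibitor of growth, a higher number a weaker inhibitor of growth), compound 1 gives 24600 nM. Compound 2 `COC(=O)[C@@H]1C[C@@]2(CC=C(C)C)c3ccccc3N3C(=N)[C@H](Cc4ccccc4)N1[C@H]32` is the starting point of the step followed here. In this assay compound 2 gives > 100000 nM, which is a limit of the assay and not a number. Compound 2 thus sits at the limit of > 100000 nM in this assay, at which 1 of the 2 values shown sits, so the two values together show a number for compound 1 and only a limit for compound 2, with nothing measured in between.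

Compound 3 `COC(=O)[C@@H]1C[C@@]2(CC=C(C)C)c3ccccc3N3C(=N)[C@H](C(C)(C)C)N1[C@H]32` follows from compound 2 by a single change: tert-butyl in place of benzyl on a saturated ring carbon. Among the measured compounds shown here, no pair of measured compounds differs in one place, so no measured step sets a scale for this change, and compound 2 itself offers no number to move from. With compound 2 already at the limit, the expected step from compound 2 to compound 3 a step that the limit leaves unreadable from compound 2 to compound 3 is none beyond the scatter. Compound 3 is therefore estimated in this assay at 120000 nM, within a range of 30000 nM to 400000 nM, with a considerable chance that only a limit is reported again.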

Compound 3, concentration for total growth inhibition: 26200 nM
The estimate for compound 3 lay 4.6-fold (0.66 log units) above the measured number; the whole stated range lies above it.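

In this assay, tert-butyl in place of benzyl on a saturated ring carbon gives an at least 3.8-fold lower number from compound 2 to compound 3 (0.58 log units; beyond the scatter), which shows that the group carried on this carbon of the five-membered non-aromatic ring with 2 nitrogen can shift the read-out beyond the scatter, and that a group with no ring can bring this core into the numerical range. Compound 2 stands at a limit of the assay and not at a number, so the step has a lower bound but no exact size: the limit of > 100000 nM in this assay, at which 1 of the 3 values shown sits. Compounds 1 and 2 alone offered no pair differing in one place, so this single step is the only scale for this position among the compounds shown.

The step cannot separate the loss of the aromatic ring from the drop in heavy atoms, as the two change together between benzyl and tert-butyl, and one pair cannot show whether the change carries over to other substituents on the shared core. Also open, from the compounds shown here alone, is how this carbon would read with an isopropyl group, a phenyl ring set directly on it, an amine or a carboxylic acid.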